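This account rests on a few compounds, and the source may have more. Where it says the series, first, only, none or still open, it means among the compounds named here.

Measured so far:
- compound 1 `O=C(O)c1cc(-c2cccs2)ccc1O`: a functional assay on the whole organism for inhibition, with Rattus norvegicus as the target, read by paw edema (a higher number here means that more compound is needed for the effect, a lower number that less compound is needed), 60 mg/kg
- compound 2 `O=C(O)c1ccc(-c2ncco2)cc1O`: > 250 mg/kg

Going by the values given here, compound 1 holds the only actual number in this assay. For compound 2 the entry is a limit of the assay and not a number, as the limit of > 250 mg/kg in this assay, at which 1 of the 2 values shown sits, records, so the two cannot be set against each other as a step.

Compound 3 `O=C(O)c1cc(-n2cccn2)ccc1O` is not yet measured. It differs from compound 1 in one place: 1H-pyrazol-1-yl in place of thiophen-2-yl on an aromatic carbon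

Among the compounds with values here, no step between two measured compounds differing in one place is available, so there is no measured precedent for this exchange. The expectation is a step toward a higher dose for compound 3, of a size that may reach just beyond the scatter but need not.

Compound 3 is estimated at 110 mg/kg in this assay, with a range from 40 mg/kg to 250 mg/kg, which means an expected step of a 1.8-fold higher number from compound 1 to compound 3 (0.26 log units; within the scatter).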

Compound 3, dose for half-maximal effect: 200 mg/kg
Estimate against measurement, compound 3: 1.8-fold (0.26 log units) below; measured number inside the range.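

In this assay, the position meta to a carboxy group and para to a hydroxy group now has its first readable step: 1H-pyrazol-1-yl in place of thiophen-2-yl gives a 3.3-fold higher number from compound 1 to compound 3 (0.52 log units; beyond the scatter), so this position does not treat these two five-membered aromatic rings alike. The two groups match in heavy-atom count and differ in their ring hetero atoms and hydrogen-bond acceptors, so the change at this position needs no change in group size. Going by these compounds alone, nothing measured so far accounts for this step.

Steps involving compound 2 cannot be read, as its entry is a limit of the assay and it differs from the others in more than one place. Open, going by these compounds, is how a phenyl ring, a thiophen-3-yl group or an amine at this position would compare with compound 1.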